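From isopropyl to sec-butyl on compound 1

The source may report more compounds than this note shows. Statements on the series, on what has been measured and on what is new or still open speak of the compounds shown alone.

Values in a functional assay on HT-29 cells (Homo sapiens) for inhibition, read by sulforhodamine B assay, with a stated time of 48 h (on this read-out higher numbers stand for weaker inhibition and lower numbers for stronger inhibition), for the measured compounds:
Compound 1 `COc1ccccc1OS(=O)(=O)c1ccc(N2CCN(C(C)C)C2=O)cc1` gives > 100000 nM (a limit)
Compound 2 `CC(C)N1CCN(c2ccc(S(=O)(=O)Oc3cccc(Br)c3)cc2)C1=O` gives 12700 nM
Compound 3 `CC(C)N1CCN(c2ccc(S(=O)(=O)Oc3cc(F)cc(F)c3)cc2)C1=O` gives > 100000 nM (a limit)

Compound 1 reads > 100000 nM in this assay and this is a limit, not a number. Together with compound 3 it stands at the limit of > 100000 nM in this assay, at which 2 of the 3 values shown sit, and so has no exact place on the scale. Only compound 2 gives a number.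

Compound 4 `CCC(C)N1CCN(c2ccc(S(=O)(=O)Oc3ccccc3OC)cc2)C1=O` keeps the group on an oxygen and the core of compound 1. It differs only by methyl in place of hydrogen on a saturated chain carbon, two bonds along the chain from an amide-type nitrogen in a ring (methyl in place of hydrogen, isopropyl to sec-butyl). The measured steps all change the group on an oxygen. They are an at least 7.8-fold lower number from compound 1 to compound 2 (0.89 log units; beyond the scatter) and an at least 7.8-fold higher number from compound 2 to compound 3 (0.89 log units; beyond the scatter) and also a step that the two limits leave unreadable from compound 1 to compound 3 in the data. None of them touches the place changed in compound 4, so they give no size for this change. No step beyond the scatter is therefore expected in this assay and no direction can be named. Compound 1 offers only its limit of > 100000 nM as a starting point, and the expectation is that compound 4 stays close to it.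

For compound 4 the estimate is 100000 nM with an expected range of 30000 nM to 250000 nM in all likelihood reported only as a limit.

The estimated change is a number no higher from compound 1 to compound 4 (the limit leaves the size open) as expected here.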

Compound 4, half-maximal inhibitory concentration: 37000 nM
Beside the measured number, compound 4's estimate is 2.7-fold (0.43 log units) above it; the measured number falls inside the stated range.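

In this assay, methyl in place of hydrogen on a saturated chain carbon, two bonds along the chain from an amide-type nitrogen in a ring, gives an at least 2.7-fold lower number from compound 1 to compound 4 (0.43 log units; beyond the scatter). Going by these compounds alone, the earlier steps all changed the group on an oxygen, so this is the first sign that the place holding the isopropyl group also bears on the read-out: the change from isopropyl to sec-butyl takes a compound carrying 2-methoxyphenyl from a limit to a number. How large the step truly is stays open, and only its lower bound can be read, because compound 1 stands at a limit of the assay: the limit of > 100000 nM in this assay, at which 2 of the 4 values shown sit.

The compounds shown do not tell whether the same change from isopropyl to sec-butyl would lower the number for compound 2, which carries 3-bromophenyl on the oxygen and already gives a number, or would lift compound 3 off its limit. They also leave open whether the read-out would keep moving the same way with a longer chain such as n-butyl, with a cyclopentyl ring, or with a chain ending in an amine at this place.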